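This account rests on a few compounds, and the source may have more. Where it says the series, first, only, none or still open, it means among the compounds named here.

Compound 1 `COc1ccc(C(=O)OC2CCC(CN3CCN(c4cc(=O)c5cc(C(F)(F)F)cc([N+](=O)[O-])c5s4)CC3)CC2)cc1` gives 0.295 h in an ADME assay on cells (Hepatocyte, Mus musculus) for metabolic stability; a lower number here means that the compound disappears faster, a higher number that the compound lasts longer. Compound 2 `Cc1ccc(C(=O)OC2CCC(CN3CCN(c4cc(=O)c5cc(C(F)(F)F)cc([N+](=O)[O-])c5s4)CC3)CC2)cc1` gives 0.202 h. Compound 3 `O=C(OC1CCC(CN2CCN(c3cc(=O)c4cc(C(F)(F)F)cc([N+](=O)[O-])c4s3)CC2)CC1)c1ccccc1` gives 0.903 h.

Compound 3 stands highest of the three in this assay, with a 3.1-fold higher number from compound 1 to compound 3 (0.49 log units; beyond the scatter) and a 4.5-fold higher number from compound 2 to compound 3 (0.65 log units; beyond the scatter), both steps beyond the scatter. The two groups on the aromatic ring, methoxy and methyl, differ by only a 1.5-fold lower number from compound 1 to compound 2 (0.16 log units; within the scatter), a step within the scatter.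

Compound 4 `O=C(OC1CCC(CN2CCN(c3cc(=O)c4cc(C(F)(F)F)cc([N+](=O)[O-])c4s3)CC2)CC1)c1ccc(C(F)(F)F)cc1` differs from compound 3 by trifluoromethyl in place of hydrogen on an aromatic carbon. Among the measured compounds shown here, the steps that bear on this change are the two just given: in each, the unsubstituted ring went with a modestly higher number than the substituted one, so adding a substituent to that ring went with a modestly lower number. For the measured compounds named here, no trifluoromethyl analogue has been measured, so the size of the step for this group is uncertain, but the direction from compound 3 is expected to be downward, with a 2.0-fold lower number from compound 3 to compound 4 (0.30 log units; within the scatter) expected. Compound 4 is therefore estimated at 0.45 h, in a range of 0.2 h to 1.1 h.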

Compound 4, half-life: 0.278 h
Estimate against measurement, compound 4: 1.6-fold (0.21 log units) above; the measured number falls inside the stated range.
By their numbers in this assay, from the lowest: compounds 2, 4 and 1 (each within the scatter of the next); then compound 3.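

In this assay, trifluoromethyl para to a large group joins methoxy and methyl in sitting below the unsubstituted ring, with a 3.2-fold lower number from compound 3 to compound 4 (0.51 log units; beyond the scatter), so all three substituents shown at this place go with a lower number than hydrogen, and no compound here goes against that. The three substituents themselves do not separate, since the steps to trifluoromethyl, a 1.4-fold higher number from compound 2 to compound 4 (0.14 log units; within the scatter) and a 1.1-fold lower number from compound 1 to compound 4 (0.03 log units; within the scatter), both lie within the scatter, and the clear difference in this set is therefore between hydrogen and any of these groups. Nothing measured here accounts for why these groups fall together.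

The compounds shown leave open whether an amine, a carboxylic acid or a single fluorine at this place would fall with these three or stay with compound 3. They also leave open whether these same groups would give the same step elsewhere on this ring.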